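A few compounds are considered here, and "the series" means these few. Any claim that something is new, unique, unknown or untested is made for them only; others in the source may bear on it.

Compounds measured so far:
- compound 1, `CCCCCCOc1ccc2c(Cl)ccnc2c1`: 2660 nM
- compound 2, `CCCCCCOc1ccc2c(NCCN(C)C)ccnc2c1`: 1870 nM
- compound 3, `CN(C)CCCNc1ccnc2cc(OCc3ccc(F)cc3)ccc12`: 2540 nM

These three were tested in a functional assay on DLD-1 cells (Homo sapiens) for cytotoxicity, read by MTT assay, with a stated time of 48 h; on this read-out higher numbers stand for weaker inhibition and lower numbers for stronger inhibition. Among the compounds with values here, compound 1 carries the highest number of the three, but its gap to compound 3 is within the scatter, and the only single-point step recorded, a 1.4-fold lower number from compound 1 to compound 2 (0.15 log units; within the scatter), is within the scatter as well, so none of the three can be told apart with confidence.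

Compound 4, `Clc1ccnc2cc(OCc3ccccc3)ccc12`, is not yet measured. Relative to compound 1 the change is phenyl in place of pentyl on a saturated chain carbon bound to an oxygen on an aromatic ring. Within the data shown here, no measured step alters the same part of the structure. The closest hint comes from compounds 2 and 3, which both carry an amine at the other end of the shared core while one bears a hexyl ether and the other a fluorinated benzyl ether; compound 2 gives 1870 nM and compound 3 gives 2540 nM, two numbers that lie within the scatter of each other. That comparison is indirect, because the two compounds differ in more than one place.

On this basis no change beyond the scatter is expected for the step of a 1.1-fold higher number from compound 1 to compound 4 (0.02 log units; within the scatter). Compound 4 is therefore estimated to give 2800 nM, with a likely range from 1300 nM to 6000 nM.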

Compound 4, half-maximal inhibitory concentration: 3270 nM
The estimate for compound 4 lay 1.2-fold (0.07 log units) below the measured number, within the range that was stated.
By their numbers in this assay, from the lowest: compounds 2, 3, 1 and 4 (each within the scatter of the next).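

In this assay, within the data shown here, this is the first direct comparison at this position: phenyl in place of pentyl on a saturated chain carbon bound to an oxygen on an aromatic ring gives a 1.2-fold higher number from compound 1 to compound 4 (0.09 log units; within the scatter), with the rest of the molecule unchanged. An open chain therefore gave way to a six-membered aromatic ring of carbon only, with no change in this cytotoxicity read-out that can be told apart from the scatter, whereas the earlier hint about this end of the molecule rested on compounds that differ in more than one place. No measurement is available that would explain this result.

The compounds shown leave open whether a different kind of group at this place, such as a pyridine ring or a chain ending in a carboxylic acid, would move the number beyond the scatter. On these data alone, it is also open whether phenyl and pentyl would remain this close with an amine on the shared core in place of the chloro, a question that compound 2 and compound 3 cannot settle, as they differ in more than one place.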